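From a benzylamino link to a phenoxy link

The compounds below may be only part of what the source reports. "The series", "measured", "known", "first", "only" and "open" are said of these compounds alone.

Compound 1 `COc1ccc(CNc2nc3cc(N)cc(N)c3nc2-c2ccccc2)cc1OC`: 97700 nM
Compound 2 `Nc1cc(N)c2nc(-c3ccccc3)c(NCc3ccc(F)cc3)nc2c1`: a limit, < 100000 nM

In a functional assay on SNB-75 cells (Homo sapiens) for inhibition, read by sulforhodamine B assay, with a stated time of 48 h (a lower number here means that less compound is tolerated, a higher number that more compound is tolerated), compound 1 gives 97700 nM. For compound 2 this assay reports only a limit, < 100000 nM, so compound 2 stands at the edge of what the assay can read rather than at a number. Within the data shown here, the one measured step, a step that the limit leaves unreadable from compound 1 to compound 2, swaps the aryl group on the benzylic carbon, and its size cannot be read because of the limit of < 100000 nM in this assay, at which 1 of the 2 values shown sits.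

Compound 3 `Nc1cc(N)c2nc(-c3ccccc3)c(Oc3ccc(F)cc3)nc2c1` differs from compound 2 by 4-fluorophenoxy in place of (4-fluorobenzyl)amino on an aromatic carbon. Among the measured compounds shown here, the single measured step touches a different part of the molecule and is itself unreadable, so it gives no guidance on the size or direction of this change. With both measured compounds sitting at or close to the limit, the expected step of a number no lower from compound 2 to compound 3 (the limit leaves the size open) is none beyond the scatter. Compound 3 is therefore expected to give about 100000 nM in this assay, within a range of 30000 nM to 300000 nM, with a fair chance that only a limit is reported.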

Compound 3, concentration lethal to 50% of the cells: < 100000 nM
Compound 3: a limit, no number; the forecaster's own chance of this, stated with the estimate: 60%; the middle value sits exactly at the limit.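

In this assay compound 3 gives only a limit, < 100000 nM. Among these compounds, compound 2 also gives only a limit, so no step from compound 2 to compound 3 can be read, because both values stop at the same edge: the limit of < 100000 nM in this assay, at which 2 of the 3 values shown sit. On these data alone, whether the 4-fluorophenoxy link changes the result at all, and in which direction, stays open.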